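Trimming the carboxycarbonyl group of compound 2

The compounds below may be only part of what the source reports. "The series", "measured", "known", "first", "only" and "open" are said of these compounds alone.

Going by the values given here, in a functional assay on HEL cells (Homo sapiens) (on this read-out higher numbers stand for lower toxicity in this test and lower numbers for higher toxicity in this test), compound 1 `Cc1cn([C@@H]2O[C@H](CO[Si](C)(C)C(C)(C)C)[C@@]3(OS(=O)(=O)C=C3NC(N)=O)[C@H]2O[Si](C)(C)C(C)(C)C)c(=O)n(C)c1=O` gives 11000 nM, and compound 2 `Cc1cn([C@@H]2O[C@H](CO[Si](C)(C)C(C)(C)C)[C@@]3(OS(=O)(=O)C=C3NCC(=O)C(=O)O)[C@H]2O[Si](C)(C)C(C)(C)C)c(=O)n(C)c1=O` gives 146000 nM, the higher of the two numbers measured so far. Among the compounds with values here, the only measured step is a 13-fold higher number from compound 1 to compound 2 (1.12 log units; beyond the scatter), with (carboxycarbonyl)methyl in place of carbamoyl on an amine nitrogen.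

Compound 3 `Cc1cn([C@@H]2O[C@H](CO[Si](C)(C)C(C)(C)C)[C@@]3(OS(=O)(=O)C=C3NCCC(=O)O)[C@H]2O[Si](C)(C)C(C)(C)C)c(=O)n(C)c1=O` keeps the shared core and carries carboxymethyl in place of carboxycarbonyl on a saturated chain carbon bound to an amine nitrogen. Cut one bond further out, the same difference reads (carboxycarbonyl)methyl to 2-carboxyethyl.

The measured step bears on this change only in part. Within the data shown here, it exchanged the whole substituent on the same nitrogen, whereas here the carboxy part stays, and no measured pair isolates the present change. In this assay, a much smaller step than that one is therefore expected, most likely within the scatter and, if anything, towards a lower number: a 1.5-fold lower number from compound 2 to compound 3 (0.16 log units; within the scatter). Compound 3 is estimated at 100000 nM, with an expected range from 30000 nM to 250000 nM.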

Compound 3, half-maximal cytotoxic concentration: 34000 nM
Compound 3: the middle estimate sits 2.9-fold (0.47 log units) above what was measured; measured number inside the range.
By their numbers in this assay, from the lowest: compound 1; then compound 3; then compound 2.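

In this assay, carboxymethyl in place of carboxycarbonyl on a saturated chain carbon bound to an amine nitrogen gives a 4.3-fold lower number from compound 2 to compound 3 (0.63 log units; beyond the scatter), so this position responds even when the carboxy part stays and only the rest of the group changes. The earlier step, a 13-fold higher number from compound 1 to compound 2 (1.12 log units; beyond the scatter), exchanged the whole substituent and could not show this. Against carbamoyl on the same amine nitrogen, 2-carboxyethyl still gives a 3.1-fold higher number from compound 1 to compound 3 (0.49 log units; beyond the scatter), so both carboxy-bearing substituents shown stand above compound 1, and the one with a single double bond outside aromatic rings keeps only part of the distance reached by compound 2. Nothing available explains the size of either step.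

The compounds shown leave open how the read-out would move with a methyl ester or a primary amide in place of the carboxylic acid, or with a longer chain carrying that acid. They also leave open whether a hydroxyl group on the chain, in place of the carbonyl that compound 2 carries, would fall nearer compound 2 or compound 3.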